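A few compounds are considered here, and "the series" means these few. Any claim that something is new, unique, unknown or untested is made for them only; others in the source may bear on it.

Measured compounds:
compound 1 `N#Cc1ccc(-c2cs/c(=N/NC(=O)CSc3ncccn3)n2-c2ccccc2)cc1`; in an ADME assay on NIH3T3 cells (Mus musculus) for cytotoxicity, read by MTT assay, with a stated time of 24 h (on this read-out lower numbers stand for stronger inhibition and higher numbers for weaker inhibition), compound 1 reaches only the limit < 3.9 ug/mL.
compound 2 `Cc1ccc(-c2cs/c(=N/NC(=O)CSc3nnnn3C)n2-c2ccccc2)cc1`; in this assay compound 2 gives 243 ug/mL.
compound 3 `Cn1cnnc1SCC(=O)N/N=c1/scc(-c2ccc(C#N)cc2)n1-c1ccccc1`; in this assay compound 3 gives 153 ug/mL.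

Compound 3 holds the lowest of the two numbers, and compound 2, the nearest, lies within the scatter of it. Compound 1 stands apart at a limit (the limit of < 3.9 ug/mL in this assay, at which 1 of the 3 values shown sits). Going by the values given here, the one measured step, an at least 39-fold higher number from compound 1 to compound 3 (1.59 log units; beyond the scatter), was large, though it exchanged a different group on the same sulfur.

Compound 4 `Cn1nnnc1SCC(=O)N/N=c1/scc(-c2ccc(C#N)cc2)n1-c1ccccc1` differs from compound 3 by 1-methyl-1H-tetrazol-5-yl in place of 4-methyl-4H-1,2,4-triazol-3-yl on a sulfur. Among the compounds with values here, no measured step covers this exchange. Within the data shown here, compound 2 already carries the entering 1-methyl-1H-tetrazol-5-yl group, yet it differs from compound 4 elsewhere as well, so its value and that of compound 3 show only two numbers within the scatter of each other. On that basis the expected step of a 1.2-fold higher number from compound 3 to compound 4 (0.07 log units; within the scatter) stays within the scatter. Compound 4 is therefore estimated at 180 ug/mL, with a range from 80 ug/mL to 400 ug/mL.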

Compound 4, half-maximal inhibitory concentration: 213 ug/mL
Compound 4: middle estimate off by 1.2-fold (0.07 log units), on the low side, within the range that was stated.
By their numbers in this assay, from the lowest: compounds 3, 4 and 2 (each within the scatter of the next). At a limit, below all of these: compound 1.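

In this assay, 1-methyl-1H-tetrazol-5-yl in place of 4-methyl-4H-1,2,4-triazol-3-yl on the sulfur stays within the scatter, with a 1.4-fold higher number from compound 3 to compound 4 (0.14 log units; within the scatter), and cyano in place of methyl on an aromatic carbon also stays within it, with a 1.1-fold lower number from compound 2 to compound 4 (0.06 log units; within the scatter). The pyrimidin-2-yl group on the same sulfur now stands apart from both five-membered aromatic rings, since an at least 54-fold higher number from compound 1 to compound 4 (1.73 log units; beyond the scatter) is a second large step alongside an at least 39-fold higher number from compound 1 to compound 3 (1.59 log units; beyond the scatter). The value of compound 1 is a limit: the limit of < 3.9 ug/mL in this assay, at which 1 of the 4 values shown sits.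

The compounds shown leave open whether a phenyl or a pyridin-2-yl group on the sulfur would fall with pyrimidin-2-yl or with the five-membered rings. They also leave open whether an amine or a carboxylic acid in place of cyano would stay within the scatter.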